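The source may hold more compounds than are shown below. What is called first, only, known or untested is meant among the compounds shown, and "the series" means these compounds.

Measured in a functional assay on MT4 cells (Homo sapiens) for cytotoxicity; on this read-out lower numbers stand for stronger inhibition and higher numbers for weaker inhibition:

Compound 1, `Cc1ccccc1Sc1cccc(N)c1C#N`, gives > 40000 nM, which is a limit of the assay and not a number.
Compound 2, `Cc1ccc(Sc2cccc(N)c2C#N)cc1`, gives > 200000 nM, also a limit of the assay.
Compound 3, `N#Cc1c(N)cccc1Sc1ccccc1Cl`, gives 33000 nM.

Compound 1 and compound 3 differ in one place: chloro in place of methyl on an aromatic carbon. This change made a step of an at least 1.2-fold lower number from compound 1 to compound 3 (0.08 log units; that floor lies within the scatter). The step is known only as a floor because compound 1 sits at the limit of > 40000 nM in this assay, at which 1 of the 3 values shown sits. The values of compound 1 and compound 3 lie within the usual scatter of each other, so no order can be read between them.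

Compound 2 shares its atoms with compound 1, joined differently; how the two cores differ is not broken down here. Compound 4, `N#Cc1c(N)cccc1Sc1ccc(Cl)cc1`, is not yet measured. It differs from compound 2 by chloro in place of methyl on an aromatic carbon. This is the same kind of change as that from compound 1 to compound 3, but the place is not the same: there the chloro enters ortho to a large group, here para to a large group.

Because compound 2 sits at the limit of > 200000 nM in this assay, at which 1 of the 3 values shown sits, only a floor is known for its starting point. On the earlier step, which stayed within the scatter, the step from compound 2 to compound 4 in this assay is expected to be about an at least 1.3-fold lower number from compound 2 to compound 4 (0.12 log units; that floor lies within the scatter). Compound 4 is therefore estimated at 150000 nM, between 40000 nM and 300000 nM, with a fair chance that the assay again reports only a limit.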

Compound 4, half-maximal inhibitory concentration: 113000 nM
For compound 4 the middle estimate is 1.3-fold (0.12 log units) above the measured one, and the stated range covers the measured number.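

The swap of methyl for chloro, here para to a large group, gives an at least 1.7-fold lower number from compound 2 to compound 4 (0.24 log units; that floor lies within the scatter) in this assay. Set beside the same swap on the other core, it shows that both steps point to a lower number, but each is known only as a floor that stays within the scatter, so neither pair proves a real effect of the swap, and no claim can be made that the step carries over with a fixed size: the same change on two cores in this assay, an at least 1.2-fold lower number (0.08 log units; that floor lies within the scatter) from compound 1 to compound 3 and an at least 1.7-fold lower number (0.24 log units; that floor lies within the scatter) from compound 2 to compound 4; the limit leaves it open whether they differ

On these data alone, compound 2 gives > 200000 nM, which is a limit of the assay and not a number, so the true size of the new step remains unknown, and the chloro also enters at a different place in each of the two pairs, which means that this comparison does not test the core alone.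

The compounds shown carry only methyl or chloro on this ring, so they leave open what a bromo, a methoxy or a carboxylic acid at the same place would do to the number. They also leave open whether the swap would give a step beyond the scatter on a core whose starting compound has a measured number rather than a limit.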